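This account rests on a few compounds, and the source may have more. Where it says the series, first, only, none or still open, it means among the compounds named here.

Measured so far: compound 1 `CN(C)C1CCN(c2cccc3nc(CN(C)[C@H]4CCCc5cccnc54)cn23)CC1` with 3400 nM; compound 2 `CCCN(Cc1cn2c(N3CCN(C)CC3)cccc2n1)[C@H]1CCCc2cccnc21` with 6700 nM; compound 3 `CN1CCN(c2cccc3nc(CN(C)[C@H]4CCCc5cccnc54)[nH]c23)CC1` with > 5000 nM.

In an ADME assay on HOS cells (Homo sapiens) for cytotoxicity (on this read-out higher numbers stand for lower toxicity in this test and lower numbers for higher toxicity in this test), compound 1 and compound 2 give numbers that lie within the scatter of each other, so they cannot be told apart on this test. For compound 3 the result is a limit of the assay and not a number (the limit of > 5000 nM in this assay, at which 1 of the 3 values shown sits). Compound 4 `CC(C)N1CCN(c2cccc3nc(CN(C)[C@H]4CCCc5cccnc54)cn23)CC1` has not been measured yet; it differs from compound 1 in one place (4-isopropylpiperazin-1-yl in place of 4-(dimethylamino)piperidin-1-yl on an aromatic carbon). Among the measured compounds shown here, no measured pair shows the effect of such a change, so the step from compound 1 to compound 4 is expected to be small, no larger than the scatter, in either direction. For compound 4 the expected value is 4000 nM, with a likely range from 1500 nM to 12000 nM, meaning an expected step of a 1.2-fold higher number from compound 1 to compound 4 (0.07 log units; within the scatter).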

Compound 4, half-maximal cytotoxic concentration: 7100 nM
For compound 4 the middle estimate is 1.8-fold (0.25 log units) below the measured one, and the stated range covers the measured number.
By their numbers in this assay, from the lowest: compounds 1, 2 and 4 (each within the scatter of the next, the first and the last beyond it).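

In this assay, among the compounds shown here, 4-isopropylpiperazin-1-yl in place of 4-(dimethylamino)piperidin-1-yl gives the first single-place step at this position: a 2.1-fold higher number from compound 1 to compound 4 (0.32 log units; beyond the scatter). The number here therefore responds to this exchange, even though both groups carry the same counted heavy atoms, donors and acceptors; the step is modest and rests on a single pair. Nothing in the data shown accounts for the step. From the compounds shown here alone, how a morpholine ring or a primary amine in this place would read remains open. So does whether the same exchange would give a similar step on another core.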